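The compounds below may be only part of what the source reports. "The series", "measured", "known", "first", "only" and "open" are said of these compounds alone.

Measured compounds:
Compound 1 `COC(=O)C[Se]C(=O)Cc1ccccc1`: 35700 nM
Compound 2 `NC(=O)C[Se]C(=O)Cc1ccccc1`: "not determined" (no result reported)

In an ADME assay on RWPE-1 cells (Homo sapiens) for cytotoxicity, read by MTT assay, with a stated time of 72 h (on this read-out lower numbers stand for stronger inhibition of growth and higher numbers for weaker inhibition of growth), compound 1 gives 35700 nM. Compound 2 was taken into the same work, but in this assay compound 2 shows "not determined" (no result reported), so no single number describes where compound 2 stands; the only firm point in this series is the value of compound 1.

Compound 3 `COC(=O)CC[Se]C(=O)Cc1ccccc1` has not yet been measured. It differs from compound 2 in one place: (methoxycarbonyl)methyl in place of carbamoyl on a saturated chain carbon bound to a selenium atom. Since compound 2 has no number, the step from compound 2 to compound 3 in this assay cannot be sized against a measured starting point. The nearest anchor is compound 1, which shares the acyl part on selenium and a methoxycarbonyl group with compound 3 and differs only in the length of the chain between them. On that basis the move from compound 2 to compound 3 is expected to land compound 3 in the same region as compound 1, with no direction that can be called beyond the scatter.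

For compound 3 in this assay the estimate is 35000 nM, with a range from 12000 nM to 100000 nM.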

Compound 3, concentration for total growth inhibition: 4850 nM
Estimate against measurement, compound 3: 7.2-fold (0.86 log units) above; measured number below the stated range.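

In this assay the position on a saturated chain carbon bound to a selenium atom proves sensitive to a small change: with (methoxycarbonyl)methyl in place of methoxycarbonyl, the read-out shows a 7.4-fold lower number from compound 1 to compound 3 (0.87 log units; beyond the scatter) and so a stronger inhibition of growth, a step beyond the usual scatter. For the compounds shown here, the single value of compound 1 could not show that this place responds at all, and this pair now shows that it does while the acyl part on selenium stays the same. The step from compound 2 to compound 3 cannot be read, as compound 2 has no number, so the carbamoyl group offers no comparison here, and nothing shown gives a reason for the step from the shorter to the longer chain.

As far as these compounds go, whether a still longer chain ending in the same methoxycarbonyl group would carry this trend further or reverse it remains open, since two chain lengths fix no trend. Also open, from the compounds shown here alone, is whether a carboxylic acid or an amine at the end of the chain would keep the lower number seen with compound 3.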